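Series notes: heteroaryl thioether swap on the ketone chain

A few compounds are considered here, and "the series" means these few. Any claim that something is new, unique, unknown or untested is made for them only; others in the source may bear on it.

Compound 1 `CC(C)c1cc(OCC(=O)[C@H](CC(=O)O)NC(=O)[C@@H](NC(=O)COc2cccc3ccccc23)C(C)C)no1`; in a functional assay on Jurkat cells (Homo sapiens) for inhibition (on this read-out higher numbers stand for weaker inhibition and lower numbers for stronger inhibition), compound 1 gives > 200000 nM, which is a limit of the assay and not a number.
Compound 2 `CC(C)[C@H](NC(=O)COc1cccc2ccccc12)C(=O)N[C@@H](CC(=O)O)C(=O)CSc1nncn1C`; in this assay compound 2 gives > 200000 nM, again a limit of the assay.

Compound 2 therefore stands at a limit in this assay only; no number is known for it. Within the data shown here, the one measured step, a step that the two limits leave unreadable from compound 1 to compound 2, cannot be read, as both of its ends are limits.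

Compound 3 `CC(C)[C@H](NC(=O)COc1cccc2ccccc12)C(=O)N[C@@H](CC(=O)O)C(=O)CSc1nnnn1-c1ccccc1` differs from compound 2 by 1-phenyl-1H-tetrazol-5-yl in place of 4-methyl-4H-1,2,4-triazol-3-yl on a sulfur. No readable measured step bears on this change. Among the measured compounds shown here, the only guidance is the limit of > 200000 nM in this assay, at which 2 of the 2 values shown sit, which leaves the size and direction of any step in this assay open, so no step beyond the scatter can be argued for.

On that basis compound 3 is expected to sit near the limit as well, estimated at 200000 nM with a range from 50000 nM to 800000 nM. The expected step from compound 2 to compound 3 is a number no higher from compound 2 to compound 3 (the limit leaves the size open), and a further limit rather than a number is the likely outcome.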

Compound 3, half-maximal inhibitory concentration: 153000 nM
For compound 3 the middle estimate is 1.3-fold (0.12 log units) above the measured one; the measured number falls inside the stated range.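

In this assay compound 3 gives 153000 nM, the only actual number among the compounds shown, so a readable value is reached with (1-phenyl-1H-tetrazol-5-yl)sulfanyl on the saturated chain carbon. The change on the sulfur gives an at least 1.3-fold lower number from compound 2 to compound 3 (0.11 log units; that floor lies within the scatter), and the change from the (5-isopropyl-1,2-oxazol-3-yl)oxy group gives an at least 1.3-fold lower number from compound 1 to compound 3 (0.11 log units; that floor lies within the scatter); both are floors, so neither establishes a step beyond the scatter, and the step between the two limits cannot be read. The series otherwise remains at the limit: the limit of > 200000 nM in this assay, at which 2 of the 3 values shown sit.

The compounds shown do not separate the contribution of the tetrazole ring from that of its phenyl ring. From the compounds shown here alone, a 1-methyl-1H-tetrazol-5-yl group on the sulfur would bear on that question, and its value in this assay remains open.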